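Methyl on the benzyl ether: compound 2 to compound 4

The compounds below may be only part of what the source reports. "The series", "measured", "known", "first", "only" and "open" are said of these compounds alone.

Measured so far:
compound 1, `O/N=C1/C(c2c[nH]c3ccc(OCc4ccccc4)cc23)=Nc2ccc(OCc3ccccc3)cc21`, in a functional assay on NCI-H460 cells (Homo sapiens) for cytotoxicity, read by MTT assay, with a stated time of 2 days; a higher number here means a weaker inhibitor, a lower number a stronger inhibitor: 16600 nM
compound 2, `Fc1ccc2c(c1)/C(=N\OCc1ccccc1)C(c1c[nH]c3ccc(F)cc13)=N2`, in this assay: 12000 nM
compound 3, `N#Cc1ccc2c(c1)/C(=N\OCc1ccccc1)C(c1c[nH]c3ccc(C#N)cc13)=N2`, in this assay: 14500 nM

Compound 2 carries the lowest of the three numbers in this assay. Its nearest neighbour is compound 3 and its furthest is compound 1, and both of these gaps fall within the usual scatter of repeated measurements, so the three compounds cannot be placed in any order on these data. All three sit in the same weak range, and nothing here distinguishes the fluoro pair from the nitrile pair or from the benzyloxy pair.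

Compound 4, `Cc1ccc(CO/N=C2/C(c3c[nH]c4ccc(F)cc34)=Nc3ccc(F)cc32)cc1`, differs from compound 2 by methyl in place of hydrogen on an aromatic carbon, read one bond further out as benzyloxy to (4-methylbenzyl)oxy. For the measured compounds named here, no pair of measured compounds shows this change, so there is no step to lean on. For a change of this size on the benzyl ether, with the three measured compounds all close together, no step beyond the scatter is expected in this assay in either direction; the expected step is a 1.1-fold lower number from compound 2 to compound 4 (0.04 log units; within the scatter). Compound 4 is estimated at 11000 nM, with a range from 5000 nM to 25000 nM.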

Compound 4, half-maximal inhibitory concentration: 12000 nM
Compound 4: middle estimate off by 1.1-fold (0.04 log units), on the low side; the measured number falls inside the stated range.
By their numbers in this assay, from the lowest: compounds 2, 4, 3 and 1 (each within the scatter of the next).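

In this assay, methyl in place of hydrogen on an aromatic carbon of the benzyl ether, benzyloxy to (4-methylbenzyl)oxy, gives no change at the digits printed from compound 2 to compound 4 (within the scatter). For the compounds shown here, this is the only step that isolates one change, since the earlier compounds differ from one another in more than one place and could not show what this position does alone. On this single pair, the place para to a large group accepts one added methyl with no readable change in the number, and no measurement in hand offers an explanation for this flat step.

Going by these compounds, one methyl gives little sense of how far this tolerance extends, so it remains open whether an amine, a carboxylic acid or a longer chain in the same place would also leave the number unmoved or would shift it beyond the scatter. On these data alone, it is also open whether the same methyl gives the same flat step on the benzyl ether of compound 3, where the fluoro groups of compound 2 are replaced by nitrile.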